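From tert-butoxycarbonyl to ethoxycarbonyl on a shared core

The compounds below may be only part of what the source reports. "The series", "measured", "known", "first", "only" and "open" are said of these compounds alone.

Three measured compounds share one core and differ only in the group on an oxygen next to a carbonyl group. Compound 1 `CC(C)COC(=O)N1CCN(C(=O)c2nc(Nc3cc(C4CC4)[nH]n3)c3cc(Cl)ccc3n2)C[C@H]1C` gives 46.9% in an assay for inhibition of serine/threonine-protein kinase PAK 4 (Homo sapiens), read by FRET and Z'-LYTE, with a stated time of 60 min, tested at 50 uM, in the presence of a further agent that is not named here; on this read-out lower numbers stand for a weaker effect and higher numbers for a stronger effect at the one concentration tested. Compound 2 `C[C@@H]1CN(C(=O)c2nc(Nc3cc(C4CC4)[nH]n3)c3cc(Cl)ccc3n2)CCN1C(=O)OC(C)(C)C` gives 36.4% in this assay, the lowest of the three numbers, and compound 3 `C[C@@H]1CN(C(=O)c2nc(Nc3cc(C4CC4)[nH]n3)c3cc(Cl)ccc3n2)CCN1C(=O)OCC(Cl)(Cl)Cl` gives 82.8% there, the highest. The steps are a number 10.5 percentage points lower from compound 1 to compound 2 (beyond the scatter) and a number 46.4 percentage points higher from compound 2 to compound 3 (beyond the scatter), with a number 35.9 percentage points higher from compound 1 to compound 3 (beyond the scatter) linking the outer pair.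

Compound 4 `CCOC(=O)N1CCN(C(=O)c2nc(Nc3cc(C4CC4)[nH]n3)c3cc(Cl)ccc3n2)C[C@H]1C` has not yet been measured. It differs from compound 2 by ethyl in place of tert-butyl on an oxygen next to a carbonyl group. Going by the values given here, no measured step exchanges tert-butyl for ethyl directly. The step of a number 10.5 percentage points lower from compound 1 to compound 2 (beyond the scatter) shows that exchanging one four-carbon group for another moved the number only modestly, while the large step of a number 46.4 percentage points higher from compound 2 to compound 3 (beyond the scatter) came only with 2,2,2-trichloroethyl. On that basis a modest rise from compound 2 is expected for compound 4, a number 8.6 percentage points higher from compound 2 to compound 4 (within the scatter), landing near the level of compound 1 rather than compound 3. Compound 4 is therefore estimated at 45% in this assay, within a range of 25% to 68%.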

Compound 4, a percentage reported as inhibition, at one concentration (the size of the read-out at that concentration, not a potency): 93.4%
Compound 4: the middle estimate sits 48.4 percentage points below what was measured; the measured number lies above the stated range.
By their numbers in this assay, from the lowest: compound 2; then compound 1; then compound 3; then compound 4.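

With ethyl in place of tert-butyl on the oxygen next to a carbonyl group, this assay records a number 57 percentage points higher from compound 2 to compound 4 (beyond the scatter) as a large step, showing that this position can respond strongly to a change that brings in no chlorine. The comparison with the isobutyl carbamate gives a number 46.5 percentage points higher from compound 1 to compound 4 (beyond the scatter) as another large step, while a number 10.6 percentage points higher from compound 3 to compound 4 (beyond the scatter) places compound 4 modestly beyond the 2,2,2-trichloroethyl compound, so the earlier large rise was not unique to that group. Nothing available here explains why ethyl and 2,2,2-trichloroethyl stand so far from tert-butyl and isobutyl.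

The compounds shown leave open where methyl or a straight propyl chain on this oxygen would fall. They also leave open whether the order seen at one concentration would hold for potency.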